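A methyl for a fluoro on the cycloheptyl compound

The source may hold more compounds than are shown below. What is called first, only, known or untested is meant among the compounds shown, and "the series" means these compounds.

In a functional assay on PC-3 cells (Homo sapiens) for cytotoxicity, read by WST assay, with a stated time of 72 h (on this read-out higher numbers stand for weaker inhibition and lower numbers for stronger inhibition), compound 1 (`O=C1Nc2c(ccc(F)c2F)C1(c1ccc(O)cc1)c1ccc(F)c(F)c1`) gives 19 nM, compound 2 (`O=C1Nc2c(ccc(F)c2F)C1(c1ccc(O)cc1)C1CCCC1`) gives 8.2 nM and compound 3 (`O=C1Nc2c(ccc(F)c2F)C1(c1ccc(O)cc1)C1CCCCCC1`) gives 12 nM. Compound 3 therefore lies within the scatter of both other compounds. Compound 4 (`Cc1c(F)ccc2c1NC(=O)C2(c1ccc(O)cc1)C1CCCCCC1`) differs from compound 3 as follows: methyl in place of fluoro on an aromatic carbon. It carries methyl in place of fluoro on an aromatic carbon.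

Within the data shown here, no measured step changes that aromatic carbon. All three change the group on a saturated ring carbon, so they bear on the new change only indirectly. The step of a 2.3-fold lower number from compound 1 to compound 2 (0.36 log units; beyond the scatter) is modest, while a 1.6-fold lower number from compound 1 to compound 3 (0.20 log units; within the scatter) and a 1.5-fold higher number from compound 2 to compound 3 (0.17 log units; within the scatter) stay within the scatter. Among the measured compounds shown here, with no direct precedent, no step beyond the scatter is expected in this assay, and the data give no firm direction. The expected step is a 1.2-fold higher number from compound 3 to compound 4 (0.07 log units; within the scatter). For compound 4 the estimated value is 14 nM, with an expected range from 5 nM to 40 nM.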

Compound 4, half-maximal inhibitory concentration: 30 nM
Compound 4: middle estimate off by 2.1-fold (0.33 log units), on the low side; the range from low to high includes it.
By their numbers in this assay, from the lowest: compounds 2, 3, 1 and 4 (each within the scatter of the next, the first and the last beyond it).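

In this assay, among these compounds, methyl in place of fluoro on this aromatic carbon gives a 2.5-fold higher number from compound 3 to compound 4 (0.40 log units; beyond the scatter), so a position that no earlier step touched does affect the read-out. The step is modest, but it lies beyond the scatter. The two groups match in every count available here (heavy atoms, hydrogen-bond donors and acceptors, net charge), so those counts do not separate them, and nothing measured here accounts for the step.

Going by these compounds, it remains open whether the same exchange would give a similar step with cyclopentyl or 3,4-difluorophenyl in place of cycloheptyl on the saturated ring carbon. The compounds shown also leave open how this aromatic carbon would respond to a hydrogen, a chloro, a methoxy or an amine, and so whether fluoro is the better group there or only better than methyl.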